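Adding a Third Methoxy Group to Compound 2

The source may report more compounds than this note shows. Statements on the series, on what has been measured and on what is new or still open speak of the compounds shown alone.

Compound 1 `Cc1cc(O)c(C2=NN(c3ccc(S(N)(=O)=O)cc3)C(c3ccccc3O)C2)cc1Cl` and compound 2 `COc1ccc(C2CC(c3cc(Cl)c(C)cc3O)=NN2c2ccc(S(N)(=O)=O)cc2)cc1OC` share the same core and differ only in the group attached to a saturated ring carbon. In a functional assay on NCI-H460 cells (Homo sapiens) for antiproliferative activity, with a stated time of 48 h (a higher number here means that more compound is tolerated, a lower number that less compound is tolerated), compound 1 gives 9400 nM, and compound 2 gives 22000 nM. Going by the values given here, the step of a 2.3-fold higher number from compound 1 to compound 2 (0.37 log units; beyond the scatter) is the only measured step in this set, and compound 2 stands with the higher of the two numbers in this assay, compound 1 being its only comparator.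

Compound 3 `COc1ccc(C2CC(c3cc(Cl)c(C)cc3O)=NN2c2ccc(S(N)(=O)=O)cc2)c(OC)c1OC` has not yet been measured. It differs from compound 2 by methoxy in place of hydrogen on an aromatic carbon. Among the compounds with values here, no measured step mirrors this change: the step of a 2.3-fold higher number from compound 1 to compound 2 (0.37 log units; beyond the scatter) exchanges the whole group on the saturated ring carbon rather than adding one methoxy to it, so it bears on the new step only loosely, and it shows that changes in this part of the molecule have so far moved the numbers only modestly. On the numbers at hand the step expected in this assay is a 1.1-fold higher number from compound 2 to compound 3 (0.06 log units; within the scatter), which is to say none beyond the scatter. Compound 3 is therefore expected to give about 25000 nM, within a range from 10000 nM to 60000 nM.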

Compound 3, concentration lethal to 50% of the cells: 7260 nM
Compound 3: the middle estimate sits 3.4-fold (0.54 log units) above what was measured; measured number below the stated range.
By their numbers in this assay, from the lowest: compounds 3 and 1 (each within the scatter of the next); then compound 2.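

In this assay, methoxy in place of hydrogen, on the aromatic carbon ortho to a large group and ortho to a methoxy group, gives a 3.0-fold lower number from compound 2 to compound 3 (0.48 log units; beyond the scatter) and so moves the number beyond the scatter, in the direction opposite to a 2.3-fold higher number from compound 1 to compound 2 (0.37 log units; beyond the scatter) on the same ring position of the molecule. Exchanging the whole group, 2,3,4-trimethoxyphenyl in place of 2-hydroxyphenyl, gives a 1.3-fold lower number from compound 1 to compound 3 (0.11 log units; within the scatter) and lies within the scatter, so that compound 2, with its 3,4-dimethoxyphenyl, alone stands apart with the highest number of the three. Nothing available explains why one added methoxy reverses the earlier step.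

The compounds shown leave open whether the step belongs to this place on the ring or merely to the presence of a third methoxy group, as the same methoxy at another free aromatic carbon would be needed to tell these apart. They also leave open whether an ethoxy group or an amine on this same aromatic carbon would follow the methoxy, and whether the step holds in any other cell line.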